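Cytotoxicity of a substituted phenylurea on blood cells

The compounds below may be only part of what the source reports. "The series", "measured", "known", "first", "only" and "open" are said of these compounds alone.

Three compounds share one core and differ only in the ring attached to the urea nitrogen. Compound 1 `COc1cc2c(Oc3ccc(/C=N/NC(=O)Nc4ccccc4)cc3F)ccnc2cc1OCCCN1CCCCC1` carries a plain phenyl there; in an ADME assay on PBL cells (Homo sapiens) for cytotoxicity, read by MTT assay, with a stated time of 72 h (a higher number here means a weaker inhibitor, a lower number a stronger inhibitor), compound 1 gives 25500 nM, a weak effect on the cells. Compound 2 `COc1cc2c(Oc3ccc(/C=N/NC(=O)Nc4ccc(Br)cc4)cc3F)ccnc2cc1OCCCN1CCCCC1` carries a 4-bromophenyl in the same position, but in this assay compound 2 gives "not determined" (no result reported), so no number places it relative to compound 1. Compound 3 `COc1cc2c(Oc3ccc(/C=N/NC(=O)Nc4ccc(F)cc4Br)cc3F)ccnc2cc1OCCCN1CCCCC1` has not been tested. The change from compound 2 to compound 3 is 2-bromo-4-fluorophenyl in place of 4-bromophenyl on an amide-type nitrogen: a fluorine is added to the ring and the bromine is moved. For the measured compounds named here, with no measured step, the only anchor is the weak effect of compound 1, and a change confined to the outer phenyl ring would be expected to shift this assay little, if at all, beyond the usual scatter. Compound 3 is therefore expected to give about 22000 nM in this assay, with a plausible range from 8000 nM to 60000 nM.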

Compound 3, half-maximal inhibitory concentration: 36400 nM
Beside the measured number, compound 3's estimate is 1.7-fold (0.22 log units) below it; the measured number falls inside the stated range.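

Setting 2-bromo-4-fluorophenyl in place of phenyl on an amide-type nitrogen gives a 1.4-fold higher number from compound 1 to compound 3 (0.15 log units; within the scatter) in this assay, and this is the first step that can be read at this position. It shows that the phenyl ring here can carry both a bromine and a fluorine without the cell reading moving beyond what repeated measurements would scatter by, so compound 1 and compound 3 cannot be told apart in this test. No measurement shown offers an explanation for this result.

The steps that involve compound 2 cannot be read, so the separate contributions of adding the fluorine and of placing the bromine differently remain unresolved. The compounds shown also carry only phenyl rings, bare or bearing bromine and fluorine, which leaves open whether an amine, a carboxylic acid or a longer chain on this ring would shift the reading beyond the scatter.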